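The source may report more compounds than this note shows. Statements on the series, on what has been measured and on what is new or still open speak of the compounds shown alone.

Of the compounds shown here, three built on one shared core have been tested in a functional assay on HeLa cells (Homo sapiens) for cytotoxicity, read by MTT assay, with a stated time of 24 h; a higher number here means a weaker inhibitor, a lower number a stronger inhibitor. Compound 1 `C=CC1=C(C(=O)NCc2ccccc2F)C(c2ccc(F)cc2)OC1` reaches only the ceiling of the assay, giving > 100000 nM, a limit rather than a number. Compound 2 `C=CC1=C(C(=O)NCC(C)C)C(c2ccc(F)cc2)OC1` likewise gives > 100000 nM, again a limit. Compound 3 `C=CC1=C(C(=O)Nc2ccccc2)C(c2ccc(OC)cc2)OC1` gives > 100000 nM, also a limit. Compound 2 thus sits at the limit of > 100000 nM in this assay, at which 3 of the 3 values shown sit, alongside both other compounds. The step that the two limits leave unreadable from compound 1 to compound 2 has no readable size; both of its ends are limits. Compound 4 `C=CC1=C(C(=O)NCCCCC)C(c2ccc(F)cc2)OC1` differs from compound 2 by butyl in place of isopropyl on a saturated chain carbon bound to an amide-type nitrogen. For the measured compounds named here, no measured step here has a readable size. The step that the limit leaves unreadable from compound 2 to compound 4 is estimated to stay within the scatter. Compound 4 is expected at 150000 nM, within 50000 nM to 500000 nM, most likely again reported only as a limit.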

Compound 4, half-maximal inhibitory concentration: > 100000 nM
Compound 4 gave a limit, no number; the forecaster's own chance of this, stated with the estimate: 85%; the middle value is on the limit's open side.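

Compound 4 also gives only a limit, so no step from compound 1 or compound 2 to compound 4 can be read: the limit of > 100000 nM in this assay, at which 4 of the 4 values shown sit.

The compounds shown leave open whether any change to the shared core gives a readable value in this assay.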